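Swapping the amide amine on a cinnamamide series

The source may report more compounds than this note shows. Statements on the series, on what has been measured and on what is new or still open speak of the compounds shown alone.

Compounds measured so far:
- compound 1, `NNC(=O)CCc1ccncc1-c1ccc2ccccc2c1`: 7.7 nM
- compound 2, `O=C(O)COc1ccncc1-c1ccc2ccccc2c1`: "not determined" (no result reported)
- compound 3, `O=C(/C=C/c1ccncc1-c1ccc2ccccc2c1)N1CCOCC1`: 60.3 nM

In an assay on a protein complex for inhibition of CDK8/Cyclin C (Homo sapiens), with a stated time of 1 h (on this read-out lower numbers stand for stronger inhibition and higher numbers for weaker inhibition), compound 3 gives 60.3 nM, and that is the higher of the two numbers available. Among the compounds with values here, compound 1 in this assay gives 7.7 nM, a lower number than compound 3 by a margin beyond the usual scatter; the two differ in more than one place, so no single step connects them. For compound 2 the entry in this assay reads "not determined" (no result reported), so no number is available for it.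

Compound 4, `CN(C)C(=O)/C=C/c1ccncc1-c1ccc2ccccc2c1`, keeps the unsaturated linker and the shared core of compound 3 and alters only the amide end: dimethylamino in place of morpholin-4-yl on a carbonyl carbon. Within the data shown here, no measured pair in this set isolates such an exchange, so the size of the step rests on no precedent here. The author expects the exchange to leave the number roughly where it is, possibly edging it a little lower, with a change from compound 3 to compound 4 estimated at a 1.3-fold lower number from compound 3 to compound 4 (0.13 log units; within the scatter), which is no more than the scatter would cover. Compound 4 is therefore expected to give about 45 nM in this assay, within a range from 15 nM to 150 nM.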

Compound 4, half-maximal inhibitory concentration: 30.1 nM
Beside the measured number, compound 4's estimate is 1.5-fold (0.17 log units) above it; low and high end bracket the measured number.
By their numbers in this assay, from the lowest: compound 1; then compounds 4 and 3 (each within the scatter of the next).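

In this assay the exchange of morpholin-4-yl for dimethylamino on a carbonyl carbon amounts to a 2.0-fold lower number from compound 3 to compound 4 (0.30 log units; within the scatter) and so stays inside the scatter, which shows that this amide end can give up its ring, going from 6 heavy atoms to 3, without a change that can be told from repeat measurement. The other step, with 2-(dimethylcarbamoyl)ethenyl in place of 2-(aminocarbamoyl)ethyl on an aromatic carbon, reads as a 3.9-fold higher number from compound 1 to compound 4 (0.59 log units; beyond the scatter) and does lie beyond the scatter, but it alters the linker and the amide end together, so it cannot be assigned to either one alone. Nothing at hand bears on the reason for either step.

On these data alone, what remains open is whether the difference on that aromatic carbon follows the saturated ethyl chain or the aminocarbamoyl end, which a dimethylcarbamoyl group on the ethyl chain or an aminocarbamoyl group on the ethenyl chain would separate. As far as these compounds go, it is also open how this amide end would respond to a piperidine ring, a primary amide or a carboxylic acid.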